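Hexyloxy for Hexylamino on a Diphenyl Core

A few compounds are considered here, and "the series" means these few. Any claim that something is new, unique, unknown or untested is made for them only; others in the source may bear on it.

Of the compounds shown here, three sharing one core have been tested in an assay on microsomes from liver for inhibition of sterol O-acyltransferase 1 (Rattus norvegicus); a higher number here means a weaker inhibitor, a lower number a stronger inhibitor. Compound 1 `CCCCCCn1nc(-c2ccccc2)c(-c2ccccc2)cc1=O` gives 57000 nM, compound 2 `O=c1cc(-c2ccccc2)c(-c2ccccc2)nn1C1CCCC1` gives 119000 nM, and compound 3 `CCCCCCNc1cc(-c2ccccc2)c(-c2ccccc2)nn1` gives 24000 nM, the lowest of the three numbers; compound 3 stands nearest to compound 1 and furthest from compound 2. Among the compounds with values here, the single step between compounds that differ in one place, a 2.1-fold higher number from compound 1 to compound 2 (0.32 log units; beyond the scatter), concerns the group on the ring nitrogen and does not touch the change now in question. Compound 4 `CCCCCCOc1cc(-c2ccccc2)c(-c2ccccc2)nn1` differs from compound 3 by hexyloxy in place of hexylamino on an aromatic carbon. Within the data shown here, no measured step bears on this exchange, so the expectation rests on the size of the one step seen, which was modest. Compound 4 is therefore expected to give a number close to that of compound 3, with a modest weakening as the more likely direction, a step of a 1.7-fold higher number from compound 3 to compound 4 (0.22 log units; within the scatter). The estimate for compound 4 in this assay is 40000 nM, with a range from 12000 nM to 130000 nM.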

Compound 4, half-maximal inhibitory concentration: 72000 nM
For compound 4 the middle estimate is 1.8-fold (0.26 log units) below the measured one; low and high end bracket the measured number.
By their numbers in this assay, from the lowest: compound 3; then compounds 1, 4 and 2 (each within the scatter of the next, the first and the last beyond it).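

In this assay, replacing the atom that joins the hexyl chain to this aromatic carbon changes the result: hexyloxy in place of hexylamino gives a 3.0-fold higher number from compound 3 to compound 4 (0.48 log units; beyond the scatter) and so weakens inhibition at this position. The earlier step concerned only the group on the ring nitrogen, whereas this pair keeps the six-carbon chain and the shared core and exchanges a group with 1 hydrogen-bond donor for one with 0 hydrogen-bond donors. No measurement shown explains the weakening, and the pair alone cannot assign it to the loss of the donor or to any other difference between the two groups. A methylated hexylamino group or a hexylthio group at this carbon would test the exchange further. As far as these compounds go, how a shorter chain such as butylamino or a longer one such as octylamino would compare with hexylamino also remains open.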